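Para-chloro analogue of the benzoyl ethenyl series

The source may report more compounds than this note shows. Statements on the series, on what has been measured and on what is new or still open speak of the compounds shown alone.

compound 1 `COc1ccc(/C=C/C(=O)c2cc(-c3ccc(OC)c(OC)c3)n3nc(-c4ccccc4)cc3n2)cc1` — 14900 nM
compound 2 `COc1ccc(-c2cc(/C=C/C(=O)c3ccccc3)nc3cc(-c4ccccc4)nn23)cc1OC` — 10000 nM

In a functional assay on DU-145 cells (Homo sapiens) for antiproliferative activity, read by MTT assay, with a stated time of 24 h (on this read-out lower numbers stand for stronger inhibition and higher numbers for weaker inhibition), compound 2 gives 10000 nM. The step of a 1.5-fold lower number from compound 1 to compound 2 (0.17 log units; within the scatter) lies within the scatter, so the two measured values are not separated from each other and neither compound can be called the more potent.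

Compound 3 `COc1ccc(-c2cc(/C=C/C(=O)c3ccc(Cl)cc3)nc3cc(-c4ccccc4)nn23)cc1OC` differs from compound 2 by chloro in place of hydrogen on an aromatic carbon. Within the data shown here, the single measured step, a 1.5-fold lower number from compound 1 to compound 2 (0.17 log units; within the scatter), concerns the same ring and changed the read-out only within the scatter; it involved methoxy rather than chloro, so it bears on the present change only loosely, and no measured step with chloro exists. On this basis the step from compound 2 to compound 3 is expected to be a 1.1-fold lower number from compound 2 to compound 3 (0.05 log units; within the scatter), that is, nothing beyond the scatter. Compound 3 is therefore estimated at 9000 nM, with a range from 3000 nM to 27000 nM.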

Compound 3, half-maximal inhibitory concentration: 21300 nM
Compound 3: the middle estimate sits 2.4-fold (0.37 log units) below what was measured, and the stated range covers the measured number.
By their numbers in this assay, from the lowest: compounds 2, 1 and 3 (each within the scatter of the next, the first and the last beyond it).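

In this assay, among these compounds, chloro in place of hydrogen, para to a large group on the ring of the benzoyl, gives the first step that lies beyond the scatter: a 2.1-fold higher number from compound 2 to compound 3 (0.33 log units; beyond the scatter). This position therefore responds to a substituent, modestly and towards weaker inhibition, whereas the step between the two differently built arms, a 1.4-fold higher number from compound 1 to compound 3 (0.16 log units; within the scatter), leaves compound 1 and compound 3 unseparated. No measurement that bears on the origin of the chloro step is available.

From the compounds shown here alone, only hydrogen and chloro are compared at this position, so it remains open whether the weaker inhibition is specific to chloro or would also follow from an amine, a carboxylic acid or a longer chain in the same place. Going by these compounds, it also remains open whether chloro at another carbon of this ring would give a step of similar size.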